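Swapping isopropyl for cyclopropyl on a stilbene-pyridine amide

The compounds below may be only part of what the source reports. "The series", "measured", "known", "first", "only" and "open" are said of these compounds alone.

Four compounds share a core in which an amide-bearing ring is linked through an oxygen to a ring carrying a two-carbon double bond that ends in a pyridine. Compound 1 is `CC(C)NC(=O)c1cc(Oc2ccc(/C=C/c3ccccn3)cc2)ccn1` and in a functional assay on A549 cells (Homo sapiens) for antiproliferative activity, read by CCK-8 assay, with a stated time of 48 h (a lower number here means a stronger inhibitor, a higher number a weaker inhibitor), compound 1 gives 21400 nM. Compound 2 is `O=C(NC1CC1)c1cc(Oc2ccc(/C=C/c3ccccn3)cc2)ccn1`; in this assay compound 2 gives 17300 nM. The change between them is cyclopropyl in place of isopropyl on an amide-type nitrogen, and it made a 1.2-fold lower number from compound 1 to compound 2 (0.09 log units; within the scatter). Compound 3 is `CC(C)NC(=O)c1cc(Oc2ccc(/C=C/c3ccncc3)cc2)ccn1`; in this assay compound 3 gives 20600 nM. It differs from compound 1 by pyridin-4-yl in place of pyridin-2-yl on a double-bonded chain carbon bound to a double-bonded chain carbon, a step of a 1.0-fold lower number from compound 1 to compound 3 (0.02 log units; within the scatter). Compound 4 is `O=C(NC1CC1)c1cc(Oc2ccc(/C=C/c3ccncc3)cc2)ccn1`, reached from compound 3 by the same change, (cyclopropyl in place of isopropyl on an amide-type nitrogen). Because the step of a 1.2-fold lower number from compound 1 to compound 2 (0.09 log units; within the scatter) was small, a similarly small step a 1.2-fold lower number from compound 3 to compound 4 (0.08 log units; within the scatter) is expected. Compound 4 is therefore estimated at 17000 nM, expected between 9000 nM and 34000 nM.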

Compound 4, half-maximal inhibitory concentration: 35500 nM
Beside the measured number, compound 4's estimate is 2.1-fold (0.32 log units) below it; measured number above the stated range.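

In this assay, cyclopropyl in place of isopropyl on an amide-type nitrogen now gives a 1.7-fold higher number from compound 3 to compound 4 (0.24 log units; within the scatter), and its two readings on the two cores do not differ beyond the scatter: the same change on two cores in this assay, a 1.2-fold lower number (0.09 log units; within the scatter) from compound 1 to compound 2 and a 1.7-fold higher number (0.24 log units; within the scatter) from compound 3 to compound 4, 2.1-fold (0.33 log units) apart, within the scatter of two such steps

Pyridin-4-yl in place of pyridin-2-yl gives a 2.1-fold higher number from compound 2 to compound 4 (0.31 log units; beyond the scatter), a modest step, yet its two readings also do not differ beyond the scatter: the same change on two cores in this assay, a 1.0-fold lower number (0.02 log units; within the scatter) from compound 1 to compound 3 and a 2.1-fold higher number (0.31 log units; beyond the scatter) from compound 2 to compound 4, 2.1-fold (0.33 log units) apart, within the scatter of two such steps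

So these four compounds give no sign that either change behaves differently from one core to the other, but with only two readings of each change, they do not prove that it carries over unchanged.

The compounds shown leave open how a longer chain such as n-butyl, or a larger ring such as cyclohexyl, on the amide-type nitrogen would read in this assay. They also leave open how pyridin-3-yl would compare with the two pyridines shown.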